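The source may hold more compounds than are shown below. What is called first, only, known or untested is meant among the compounds shown, and "the series" means these compounds.

Measured compounds:
Compound 1, `O=C(NCc1cn(Cc2ccc(Cl)cc2)nn1)c1cn(-c2ccccc2)nc1-c1ccccc1`, giving 600 nM in a functional assay on HeLa cells (Homo sapiens) for antiproliferative activity, read by sulforhodamine B assay, with a stated time of 48 h; a lower number here means a stronger inhibitor of growth, a higher number a weaker inhibitor of growth.
Compound 2, `O=C(NCc1cn(Cc2ccc(F)cc2)nn1)c1cn(-c2ccccc2)nc1-c1ccc(Cl)cc1`, giving 2800 nM in this assay.

Compound 2 holds the highest of the two numbers shown, and the only other compound, compound 1, sits at a lower number with a gap that lies beyond the scatter. Within the data shown here, compounds 1 and 2 differ in more than one place, so no single step between them is counted; their two values simply show where each stands.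

Compound 3, `O=C(NCc1cn(Cc2ccc(Cl)cc2)nn1)c1cn(-c2ccccc2)nc1-c1ccc(Cl)cc1`, has not yet been measured. Among the measured compounds shown here, it departs from compound 2 by chloro in place of fluoro on an aromatic carbon, the ring carrying it being the one where the group sits para to a large group. For the measured compounds named here, with no counted step of this kind among the measured compounds, the size of the step is open; an exchange of one halogen for another at this place is expected to move this assay little, perhaps toward a somewhat lower number, and plausibly not beyond the scatter. On that basis the estimate for compound 3 is 2000 nM, with a range from 800 nM to 5000 nM, which corresponds to an expected step of a 1.4-fold lower number from compound 2 to compound 3 (0.15 log units; within the scatter).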

Compound 3, concentration for 50% growth inhibition: 470 nM
For compound 3 the middle estimate is 4.3-fold (0.63 log units) above the measured one; the measured number lies below the stated range.
By their numbers in this assay, from the lowest: compounds 3 and 1 (each within the scatter of the next); then compound 2.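

In this assay, among these compounds, the exchange of fluoro for chloro, which turns the 4-fluorobenzyl group into the 4-chlorobenzyl group, gives the first reading at this position with everything else held constant, and it amounts to a 6.0-fold lower number from compound 2 to compound 3 (0.78 log units; beyond the scatter). The choice of halogen on this aromatic carbon therefore matters in this pair, although that rests on a single exchange on a single background. The remaining step, in which a second chloro takes the place of a hydrogen elsewhere in the molecule, comes to a 1.3-fold lower number from compound 1 to compound 3 (0.11 log units; within the scatter), so with the 4-chlorobenzyl group present, that second chloro is not separated from hydrogen in this assay.

The compounds shown leave open how hydrogen, a methoxy group, an amine or a carboxylic acid would read at the position that carries the fluoro or chloro, and whether the exchange of fluoro for chloro would give a similar step on the background of compound 1. Nothing among the data shown offers an explanation for the size of the step from fluoro to chloro.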